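The compounds below may be only part of what the source reports. "The series", "measured", "known", "first", "only" and "open" are said of these compounds alone.

Of the compounds shown here, two with the same core have been measured in an in vitro ADME assay on microsomes from liver (Homo sapiens) for metabolic stability, using NADPH; a higher number here means faster removal of the compound, a lower number slower removal. Among the compounds with values here, compound 1 `CC(C)(CO)CNC(=O)c1cc2cc(C#N)ccc2n1Cc1cc(Cl)cc(Cl)c1` gives 103 mL.min-1.g-1 and compound 2 `Cc1ccc(Cl)cc1Cn1c(C(=O)NCC(C)(C)CO)cc2cc(C#N)ccc21` gives 119 mL.min-1.g-1, so compound 2 stands within the usual scatter of the only other measured number. Compound 3 `Cc1ccc(C)c(Cn2c(C(=O)NCC(C)(C)CO)cc3cc(C#N)ccc32)c1` comes from compound 2 by a single exchange: methyl in place of chloro on an aromatic carbon. In words, this is methyl in place of chloro on an aromatic carbon, turning 5-chloro-2-methylphenyl into 2,5-dimethylphenyl. Within the data shown here, only one measured step bears on this change, a 1.2-fold higher number from compound 1 to compound 2 (0.06 log units; within the scatter). That step altered the same aromatic group and stayed within the scatter, so a change beyond the scatter is not expected here, although one step is thin evidence. The expected step is a 1.0-fold higher number from compound 2 to compound 3 (0.00 log units; within the scatter), which would lie within the scatter. For compound 3 the estimated value is 120 mL.min-1.g-1, with an expected range of 75 mL.min-1.g-1 to 190 mL.min-1.g-1.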

Compound 3, intrinsic clearance in microsomes: 257 mL.min-1.g-1
Compound 3: the middle estimate sits 2.1-fold (0.33 log units) below what was measured; measured number outside the range, above it.
By their numbers in this assay, from the lowest: compounds 1 and 2 (each within the scatter of the next); then compound 3.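

Within the data shown here, exchanging chloro for methyl at this place on the aromatic ring is not neutral in this assay: it gives a 2.2-fold higher number from compound 2 to compound 3 (0.33 log units; beyond the scatter), the first change in this short series to pass the scatter, although only one heavy atom is exchanged. The comparison with the dichloro compound points the same way, with 2,5-dimethylphenyl in place of 3,5-dichlorophenyl giving a 2.5-fold higher number from compound 1 to compound 3 (0.40 log units; beyond the scatter), so compound 3, the only one of the three without chlorine on this ring, has the highest number, and removal is fastest for it. Nothing available here explains why this exchange raises the number.

On these data alone, it remains open whether other groups at this place, such as fluoro, methoxy or trifluoromethyl, would give numbers nearer compound 2 or nearer compound 3. A single exchange also cannot show whether the rise comes from losing the chloro or from gaining the methyl.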